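The source may report more compounds than this note shows. Statements on the series, on what has been measured and on what is new or still open speak of the compounds shown alone.

The set rests on one shared core, carried by compound 1 `CCCOC(=O)c1c(C)coc1-c1ccc2c(CC)cccc2c1OC`, compound 2 `CCc1cccc2c(OC)c(-c3occ(C)c3C(=S)OC)ccc12` and compound 3 `CCOCc1c(C)coc1-c1ccc2c(CC)cccc2c1OC`, which differ only in the group on one aromatic carbon. In a functional assay on SK-BR-3 cells (Homo sapiens) for cytotoxicity, read by MTT assay, with a stated time of 72 h (on this read-out higher numbers stand for an effect only at larger amounts of compound and lower numbers for an effect already at smaller amounts), compound 2 gives 6.3 ug/mL. For compound 1 the assay reports only a limit, > 10 ug/mL. For compound 3 likewise only a limit is known, > 10 ug/mL. Two of the three values sit at the limit of > 10 ug/mL in this assay, at which 2 of the 3 values shown sit. Compound 3 thus stands at that limit, not at a number. Among the measured steps, an at least 1.5-fold lower number from compound 1 to compound 2 (0.20 log units; that floor lies within the scatter) and an at least 1.5-fold higher number from compound 2 to compound 3 (0.20 log units; that floor lies within the scatter) are both floors that lie within the scatter, while a step that the two limits leave unreadable from compound 1 to compound 3 cannot be read at all.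

Compound 4 `CCc1cccc2c(OC)c(-c3occ(C)c3COC(=O)CCN(CC)CC)ccc12` is not yet measured. It differs from compound 3 by (2-(diethylamino)ethyl)carbonyl in place of ethyl on an oxygen on a saturated carbon. Among the measured compounds shown here, no measured step touches this position; all three known steps concern the group on the aromatic carbon, and none of them yields a readable size. The expectation for compound 4 therefore leans on where compound 3 stands, and the step of a number no higher from compound 3 to compound 4 (the limit leaves the size open) is estimated as a small one. Compound 4 is expected to give about 10 ug/mL in this assay, with a range from 4 ug/mL to 30 ug/mL.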

Compound 4, concentration for half-maximal effect: > 10 ug/mL
Compound 4: no number, only a limit (the forecaster's own chance of this, stated with the estimate: 50%); the middle value lies on the limit itself.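

In this assay compound 4 gives only a limit, > 10 ug/mL, and compound 3 also stands at a limit, so the step from compound 3 to compound 4 cannot be read. The compounds shown leave open whether (2-(diethylamino)ethyl)carbonyl in place of ethyl on an oxygen on a saturated carbon changes the read-out at all: the limit of > 10 ug/mL in this assay, at which 3 of the 4 values shown sit.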